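The compounds below may be only part of what the source reports. "The series", "measured", "known", "first", "only" and "open" are said of these compounds alone.

Compound 3, `Cc1ccccc1C(=O)N[C@@H](C(=O)N1CCC(c2ccc(Cl)cc2)CC1)C(C)C`, was measured in an assay on THP-1 cells for displacement of a labelled ligand from C-C chemokine receptor type 1 (Homo sapiens) (on this read-out higher numbers stand for weaker inhibition and lower numbers for stronger inhibition), where compound 3 gives 32 nM. Among the three compounds measured, that is the lowest number. Compound 2, `Cc1ccccc1C(=O)NC(C(=O)N1CCC(c2ccc(Cl)cc2)CC1)C(C)C`, gives 36 nM, and the step of a 1.1-fold lower number from compound 2 to compound 3 (0.05 log units; within the scatter) is the only one in which a single change separates two measured compounds; the two differ only in that one is drawn with a defined configuration at a saturated chain carbon and the other without (the fact that one of compounds 2 and 3 is drawn with a defined configuration and the other without, at the place where they differ). Compound 1, `CC[C@@H](NC(=O)c1ccccc1)C(=O)N1CCC(c2ccc(Cl)cc2)CC1`, gives 121 nM, a number clearly higher than that of compound 3, but compound 1 differs from compound 3 in more than one place, so nothing more can be read from the pair.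

Compound 4, `CC(C)[C@@H](NC(=O)CCCc1ccccc1)C(=O)N1CCC(c2ccc(Cl)cc2)CC1`, is the next compound to be measured. It differs from compound 3 by 3-phenylpropyl in place of 2-methylphenyl on a carbonyl carbon. Among the measured compounds shown here, no measured step involves a change of this kind: the one measured step concerns only the drawing of a stereocentre, not the group on the carbonyl carbon, so it offers no guide here. The expected step of a 2.2-fold higher number from compound 3 to compound 4 (0.34 log units; beyond the scatter) is therefore uncertain in direction, and compound 4 is estimated at 70 nM, within a range from 20 nM to 250 nM.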

Compound 4, half-maximal inhibitory concentration: 95 nM
The estimate for compound 4 lay 1.4-fold (0.13 log units) below the measured number; the range from low to high includes it.
By their numbers in this assay, from the lowest: compounds 3 and 2 (each within the scatter of the next); then compounds 4 and 1 (each within the scatter of the next).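

Placing 3-phenylpropyl in place of 2-methylphenyl on a carbonyl carbon gives a 3.0-fold higher number from compound 3 to compound 4 (0.47 log units; beyond the scatter), so the number responds to the group at this place, which the earlier step, concerning only how a stereocentre is drawn, could not show. The two groups share one six-membered aromatic ring of carbon only, no hydrogen-bond donors or acceptors and no net charge, so this step comes with a change in the group's carbon framework alone. Nothing available bears on what lies behind this step.

The swap removes the methyl and adds a chain at once, and the compounds shown leave open which of these matters more. On these data alone, how a shorter chain such as benzyl, or an amine or carboxylic acid on the ring, would read at this place also stays open.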